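Fluorine Count in a Side Group on a Shared Core

The source may hold more compounds than are shown below. What is called first, only, known or untested is meant among the compounds shown, and "the series" means these compounds.

In a functional assay on isolated protein for inhibition of Glucose-dependent insulinotropic receptor (Rattus norvegicus), read by HTRF and cAMP accumulation (on this read-out higher numbers stand for an effect only at larger amounts of compound and lower numbers for an effect already at smaller amounts), three compounds have been measured:
Compound 1, `Cc1nc(S(C)(=O)=O)ccc1Oc1ncnc(OC2CCN(C(=O)OC(C)C)CC2)c1F`: 142 nM
Compound 2, `Cc1nc(S(C)(=O)=O)ccc1Oc1ncnc(OC2CCN(C(=O)OC3CCC3)CC2)c1F`: 167 nM
Compound 3, `Cc1nc(S(C)(=O)=O)ccc1Oc1ncnc(OC2CCN(C(=O)O[C@@H](C)CF)CC2)c1F`: 1680 nM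

Compound 3 gives the highest number of the three. Its nearest neighbour is compound 2, a 10-fold higher number from compound 2 to compound 3 (1.00 log units; beyond the scatter); the furthest is compound 1, a 12-fold higher number from compound 1 to compound 3 (1.07 log units; beyond the scatter). Compound 4, `Cc1nc(S(C)(=O)=O)ccc1Oc1ncnc(OC2CCN(C(=O)O[C@H](C)C(F)(F)F)CC2)c1F`, differs from compound 3 in one place: 1-(trifluoromethyl)ethyl in place of 1-(fluoromethyl)ethyl on an oxygen next to a carbonyl group.

Going by the values given here, two measured steps bear on this change. Replacing the hydrogen by fluoro on the saturated chain carbon gave a 12-fold higher number from compound 1 to compound 3 (1.07 log units; beyond the scatter), a large rise, while exchanging isopropyl for cyclobutyl gave a 1.2-fold higher number from compound 1 to compound 2 (0.07 log units; within the scatter), within the scatter. Among the compounds with values here, only the step that added a fluorine moved the number, and it moved it upward. Compound 4 adds two more fluorines at the same spot, so a further rise in this assay is expected, though a single step is a thin basis and a step within the scatter cannot be excluded. For compound 4 the expected value is 2800 nM, between 800 nM and 10000 nM, which means an expected 1.7-fold higher number from compound 3 to compound 4 (0.22 log units; within the scatter).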

Compound 4, half-maximal effective concentration: 110 nM
Estimate against measurement, compound 4: 25-fold (1.41 log units) above, and the stated range ends above it.
By their numbers in this assay, from the lowest: compounds 4, 1 and 2 (each within the scatter of the next); then compound 3.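

In this assay, adding fluorine to this side group does not move the number steadily in one direction: 1-(trifluoromethyl)ethyl in place of 1-(fluoromethyl)ethyl on the oxygen gave a 15-fold lower number from compound 3 to compound 4 (1.18 log units; beyond the scatter), which undoes the rise seen with the first fluorine. The trifluorinated group also cannot be told apart from the fluorine-free groups, with a 1.5-fold lower number from compound 2 to compound 4 (0.18 log units; within the scatter) and a 1.3-fold lower number from compound 1 to compound 4 (0.11 log units; within the scatter), so among these four compounds only compound 3 stands apart. Nothing in the available data explains this reversal.

As far as these compounds go, the behaviour of 1-(difluoromethyl)ethyl, with two fluorines on that carbon, remains open, and it would show whether the number changes gradually or abruptly between one fluorine and three. From the compounds shown here alone, it is also open how a tert-butyl group would compare, and whether this pattern holds on any other core.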